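Lipophilicity notes on a fused-core amine series

This account rests on a few compounds, and the source may have more. Where it says the series, first, only, none or still open, it means among the compounds named here.

Measured so far:
compound 1 `CN(C)[C@H]1CC[C@H](Nc2ncnc3[nH]ccc23)CC1`: -0.6
compound 2 `CN(C)[C@H]1CC[C@H](Nc2ncnn3ccc([C@H]4CC[C@@H](C(N)=O)CC4)c23)CC1`: 0.1
compound 3 `CN(C)[C@H]1CC[C@H](Nc2ncnn3cccc23)CC1`: 0

In a physicochemical assay for lipophilicity, using the shake flask method, at pH 7.4 (a higher number here means a more lipophilic compound, a lower number a more polar compound), compound 1 gives -0.6, the lowest of the three numbers. Compound 3 gives 0 and compound 2 gives 0.1. The change from compound 3 to compound 2 is 4-carbamoylcyclohexyl in place of hydrogen on an aromatic carbon and the step it made was a number 0.10 log units higher from compound 3 to compound 2 (within the scatter). The difference between the core of compound 1 and the core of compound 3 is not broken down here.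

Compound 4 `CN(C)[C@H]1CC[C@H](Nc2ncnc3[nH]cc([C@H]4CC[C@@H](C(N)=O)CC4)c23)CC1` carries the same change on the core of compound 1: 4-carbamoylcyclohexyl in place of hydrogen on an aromatic carbon. Because the shown step was a number 0.10 log units higher from compound 3 to compound 2 (within the scatter), the step from compound 1 to compound 4 is expected to be a number 0.10 log units higher from compound 1 to compound 4 (within the scatter). The number expected for compound 4 in this assay is -0.5, estimated to fall between -1 and 0.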

Compound 4, distribution coefficient: 0
Compound 4: middle estimate off by 0.50 log units, on the low side, and the stated range covers the measured number.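

In this assay, 4-carbamoylcyclohexyl in place of hydrogen on an aromatic carbon gives a number 0.60 log units higher from compound 1 to compound 4 (beyond the scatter) on the core of compound 1, against a number 0.10 log units higher from compound 3 to compound 2 (within the scatter) on the core of compound 3, so the size of this step differs between the two cores. These two pairs show that the step on one core does not fix its size on the other, but they give no rule for any further core. No measurement shown accounts for the difference between the two steps.

Still open, from the compounds shown here alone, is how the two cores compare when the cyclohexyl ring carries a primary amine or a carboxylic acid in place of the carbamoyl group. Going by these compounds, a smaller group such as methyl on the same aromatic carbon is also open.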